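This account rests on a few compounds, and the source may have more. Where it says the series, first, only, none or still open, it means among the compounds named here.

Compound 1 `Cc1ccnc(-c2ccccc2OCC2=NCCN2)c1`: in a functional assay for activation of Alpha-1B adrenergic receptor (Homo sapiens), read by calcium flux (on this read-out higher numbers stand for an effect only at larger amounts of compound and lower numbers for an effect already at smaller amounts), compound 1 gives only a limit, < 100000 nM.
Compound 2 `c1ccc(-c2ccoc2)c(OCC2=NCCN2)c1`: in this assay compound 2 gives 5.01 nM.

Compound 2 thus holds the only number shown; the other value is only (the limit of < 100000 nM in this assay, at which 1 of the 2 values shown sits). Compound 3 `Cc1csc(-c2ccccc2OCC2=NCCN2)n1` differs from compound 2 by 4-methyl-1,3-thiazol-2-yl in place of furan-3-yl on an aromatic carbon, on an aromatic carbon of a six-membered aromatic ring of carbon only, ortho to a group of 7 heavy atoms. For the measured compounds named here, no measured step covers this exchange, so the expected change is modest and toward activation only at somewhat larger amounts. Compound 3 is expected to give 30 nM, between 5 nM and 300 nM. The expected step is a 6.0-fold higher number from compound 2 to compound 3 (0.78 log units; beyond the scatter).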

Compound 3, half-maximal effective concentration: < 100000 nM
Compound 3: a limit, no number; the forecaster's own chance of this, stated with the estimate: 15%; the middle value is on the limit's open side.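

In this assay, for the compounds shown here, compound 3 gives only a limit, < 100000 nM, and no step from compound 2 to compound 3 can be read. The compounds shown leave open what exchanging furan-3-yl for 4-methyl-1,3-thiazol-2-yl does to the read-out.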